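Capsaicin-like amides with sulfur groups, K562 growth inhibition

The source may hold more compounds than are shown below. What is called first, only, known or untested is meant among the compounds shown, and "the series" means these compounds.

Measured compounds:
compound 1 `COc1cc(CNC(=O)CCCCCCC(C)C)ccc1OC(=O)CCC(=O)Oc1ccc(C(N)=S)cc1` — "not determined" (no result reported)
compound 2 `COc1cc(CNC(=O)CCCCCCC(C)C)ccc1OCCCCCOc1ccc(-c2cc(=S)ss2)cc1` — > 50000 nM
compound 3 `COc1cc(CNC(=O)CCCC/C=C/C(C)C)ccc1OCCCCCOc1ccc(C(N)=S)cc1` — > 50000 nM

In a functional assay on K562 cells (Homo sapiens) for antiproliferative activity, read by MTT assay, with a stated time of 48 h (a lower number here means a stronger inhibitor, a higher number a weaker inhibitor), compound 3 gives only a limit, > 50000 nM, and no number. Compound 2 likewise gives only a limit in this assay, > 50000 nM. For compound 1 this assay holds no result, "not determined" (no result reported). Compound 3 therefore stands at the edge of what this assay resolves, together with compound 2, as shown by the limit of > 50000 nM in this assay, at which 2 of the 3 values shown sit; no ordering between the two is possible from limits.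

Compound 4 `COc1cc(CNC(=O)CCCC/C=C/C(C)C)ccc1OCCCCCOc1ccc(-c2cc(=S)ss2)cc1` is not yet measured. It differs from compound 3 by a group of 6 heavy atoms (3 carbon, 3 sulfur; one five-membered aromatic ring with 2 hetero atoms) in place of a group of 3 heavy atoms (1 carbon, 1 nitrogen, 1 sulfur; no ring), on an aromatic carbon. With the same six-atom ring-bearing group on the same aromatic carbon of compound 3's core and a saturated amide chain, compound 2 sits at the limit with > 50000 nM, so the ring-bearing group alone has not brought a compound into the measurable range. No step beyond the scatter is expected in this assay; the step from compound 3 to compound 4 is estimated as a step that the limit leaves unreadable from compound 3 to compound 4. Compound 4 is expected to remain at or beyond the limit, estimated at 80000 nM with a range of 30000 nM to 200000 nM.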

Compound 4, half-maximal inhibitory concentration: > 50000 nM
Compound 4: a limit, no number; the forecaster's own chance of this, stated with the estimate: 80%; the middle value is on the limit's open side.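

No step can be read from compound 3 to compound 4 or from compound 2 to compound 4, as all three compounds stop at one limit: the limit of > 50000 nM in this assay, at which 3 of the 4 values shown sit.

The compounds shown leave open which change to the shared core, if any, would bring a value into the measurable range.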